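Aryl ether in place of benzyl ether: stability notes

A few compounds are considered here, and "the series" means these few. Any claim that something is new, unique, unknown or untested is made for them only; others in the source may bear on it.

Two members of the series have been run so far. Compound 2 `C=CC(=O)NCc1coc(-c2c(N)ncnc2Nc2ccc(OCc3cccc(F)c3)c(Cl)c2)n1` and compound 1 `C=CC(=O)NCc1coc(-c2c(N)ncnc2Nc2ccc(OCc3ccccn3)c(F)c2)n1` share the same core but differ from each other in more than one place. In an in vitro ADME assay on microsomes from liver (Rattus norvegicus) for metabolic stability, tested at 5 uM (on this read-out lower numbers stand for a shorter-lived compound and higher numbers for a longer-lived compound), compound 2 gives 0.483 h. In this assay compound 1 gives 0.267 h, and the two numbers lie within the usual scatter of each other, so neither compound can be set above the other on this read-out.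

Compound 3 `C=CC(=O)NCc1coc(-c2c(N)ncnc2Nc2ccc(Oc3ccccc3)c(Cl)c2)n1` has not yet been measured. It differs from compound 2 by phenyl in place of 3-fluorobenzyl on an oxygen on an aromatic ring. Going by the values given here, no pair of measured compounds covers this change, so no measured step can be borrowed for it. The step from compound 2 to compound 3 in this assay is expected to stay within the scatter, a 1.2-fold higher number from compound 2 to compound 3 (0.09 log units; within the scatter), leaning if at all toward a longer-lived compound. Compound 3 is estimated at 0.6 h in this assay, with a range from 0.25 h to 1.5 h.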

Compound 3, half-life: 0.983 h
For compound 3 the middle estimate is 1.6-fold (0.21 log units) below the measured one; measured number inside the range.
By their numbers in this assay, from the lowest: compounds 1 and 2 (each within the scatter of the next); then compound 3.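

Phenyl in place of 3-fluorobenzyl on this oxygen gives the first step in the series that clears the scatter: in this assay the change reads as a 2.0-fold higher number from compound 2 to compound 3 (0.31 log units; beyond the scatter) and leans toward a longer-lived compound. The group on this oxygen therefore has a modest but readable bearing on half-life, at least between these two compounds. Nothing shown accounts for the shift.

This single step cannot separate the loss of the fluorine from the change from benzyl to phenyl, so a plain benzyl or a 3-fluorophenyl on the same oxygen would be needed to divide the two. The compounds shown also leave open whether the step carries over to a 2-pyridylmethyl ether or to a fluorine in place of the chlorine of compound 3.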